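Branching the Chain on the Core: Compound 4 Foreseen

A few compounds are considered here, and "the series" means these few. Any claim that something is new, unique, unknown or untested is made for them only; others in the source may bear on it.

Compound 1 `CCCNc1nc(C)nc2c1cnn2-c1ccccc1` and compound 2 `CCNc1nc(C)nc2c1cnn2-c1ccccc1` share their core with compound 3 `CCCCNc1nc(CC)nc2c1cnn2-c1ccccc1` and compound 4 `CCCCNc1nc(C(C)C)nc2c1cnn2-c1ccccc1`; how the core of compound 3 differs from that of compound 2 is not broken down here. In a functional assay on G-361 cells (Homo sapiens) for cytotoxicity, read by sulforhodamine B assay (a lower number here means a stronger inhibitor of growth, a higher number a weaker inhibitor of growth), compound 2 gives only a limit, > 100000 nM. Compound 1 likewise gives only a limit, > 100000 nM. The step that the two limits leave unreadable from compound 2 to compound 1 therefore has no readable size, because of the limit of > 100000 nM in this assay, at which 2 of the 3 values shown sit. In this assay, for the measured compounds named here, compound 3 gives 32000 nM, the only number among the three. Compound 4 differs from compound 3 by methyl in place of hydrogen on a saturated chain carbon bound to an aromatic carbon and a saturated chain carbon, while compound 1 differs from compound 2 by methyl in place of hydrogen on a saturated chain carbon, two bonds along the chain from a nitrogen on an aromatic ring: the same kind of change, one on a saturated chain carbon bound to an aromatic carbon and a saturated chain carbon, the other two bonds along the chain from a nitrogen on an aromatic ring. With no measured size to lean on, the expectation rests on compound 3 alone. Compound 4 is expected to give about 30000 nM in this assay, between 8000 nM and 120000 nM. That amounts to an expected step of a 1.1-fold lower number from compound 3 to compound 4 (0.03 log units; within the scatter).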

Compound 4, concentration for total growth inhibition: > 100000 nM
Compound 4: a limit, no number; the forecaster's own chance of this, stated with the estimate: 35%; middle value at least 3.3-fold (0.52 log units) from the limit.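

In this assay, as far as these compounds go, the change from ethyl to isopropyl on the core of compound 3 gives an at least 3.1-fold higher number from compound 3 to compound 4 (0.49 log units; beyond the scatter), and its full size stays unknown since compound 4 gives only a limit. The same kind of change on the core of compound 2 cannot be set beside it, because that step has no readable size: the limit of > 100000 nM in this assay, at which 3 of the 4 values shown sit. The compounds therefore show a weaker inhibitor of growth after this change on one core only, and they neither support nor contradict its carrying over to the other core.

From the compounds shown here alone, it remains open whether a different group in place of the ethyl of compound 3, such as a cyclopropyl or an amine, would keep or improve growth inhibition.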